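Halogen swap at one aromatic position in the thiazolidinone series

A few compounds are considered here, and "the series" means these few. Any claim that something is new, unique, unknown or untested is made for them only; others in the source may bear on it.

Measured compounds:
- compound 1 `O=C1NC(=S)/C(=C/c2cccc(Cl)c2)S1`: in a functional assay on HEp-2 cells (Homo sapiens) for cytotoxicity, read by MTT assay, with a stated time of 72 h, tested at 2.5 ug/mL (on this read-out lower numbers stand for less inhibition of growth and higher numbers for more inhibition of growth at the one concentration tested), compound 1 gives 5.44%
- compound 2 `O=C1NC(=S)/C(=C/c2ccccc2Br)S1`: compound 2 gives 10.3%
- compound 3 `O=C1NC(=S)/C(=C/c2ccc(Cl)c(Cl)c2)S1`: compound 3 gives 5.03%

Compound 2 holds the highest of the three numbers in this assay, but its nearest neighbour compound 1 and its furthest neighbour compound 3 both lie within the scatter of it, so no order among the three can be read. Among the measured compounds shown here, the one single-point step measured, a number 0.4 percentage points lower from compound 1 to compound 3 (within the scatter), is likewise within the scatter.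

Compound 4 `O=C1NC(=S)/C(=C/c2ccccc2F)S1` differs from compound 2 by fluoro in place of bromo on an aromatic carbon. For the measured compounds named here, no measured step exchanges one halogen for another at this position; the only step recorded, from compound 1 to compound 3, adds chloro and stays flat. With every measured number in this assay sitting in the same narrow band, the expectation for compound 4 is a step of about a number 3.3 percentage points lower from compound 2 to compound 4 (within the scatter), that is, nothing beyond the scatter. Compound 4 is therefore estimated at 7%, within 0% to 18%.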

Compound 4, percent growth inhibition at one concentration: 1.66%
Compound 4: the middle estimate sits 5.3 percentage points above what was measured; low and high end bracket the measured number.
By their numbers in this assay, from the lowest: compounds 4, 3, 1 and 2 (each within the scatter of the next).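

Among the compounds shown here, exchanging bromo for fluoro on the aromatic carbon ortho to a group of 8 heavy atoms gives a number 8.6 percentage points lower from compound 2 to compound 4 (within the scatter) in this assay and is the only halogen-for-halogen step available at this position. Even this exchange of one halogen for another, with the rest of the molecule unchanged, does not leave the scatter, so no order between the bromo and fluoro compounds can be read. No data on why the two compounds differ or match are available.

As far as these compounds go, it remains open whether a non-halogen group at this aromatic carbon, such as an amine, a carboxylic acid or a methoxy group, would give a step beyond the scatter. Also open, from the compounds shown here alone, is whether the bromo and fluoro compounds would separate at a concentration other than the single one tested.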